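The source may report more compounds than this note shows. Statements on the series, on what has been measured and on what is new or still open speak of the compounds shown alone.

Compound 1 `CCn1c(C(=O)NCC(=O)O)ccc1C(CC)(CC)c1ccc(C#CC(O)(CC)CC)c(C)c1`: 2250 nM
Compound 2 `CCn1cc(C(CC)(CC)c2ccc(C#CC(O)(CC)CC)c(C)c2)cc1C(=O)NCC(=O)OC`: 17500 nM
Compound 3 `CCN(CC)CCNC(=O)c1cc(C(CC)(CC)c2ccc(C#CC(O)(CC)CC)c(C)c2)cn1CC`: 5350 nM

In a functional assay on PC-3 cells (Homo sapiens) for antiproliferative activity, read by MTT assay, with a stated time of 72 h (on this read-out lower numbers stand for stronger inhibition and higher numbers for weaker inhibition), compound 3 gives 5350 nM, the middle of the three numbers, with compound 1 lower at 2250 nM and compound 2 higher at 17500 nM. The next compound, compound 4 `CCn1cc(C(CC)(CC)c2ccc(C#CC(O)(CC)CC)c(C)c2)cc1C(=O)NCCN(C)C`, changes one small part of compound 3: dimethylamino in place of diethylamino on a saturated chain carbon, two bonds along the chain from an amide-type nitrogen. In words, dimethylamino takes the place of diethylamino on a saturated chain carbon, two bonds along the chain from an amide-type nitrogen.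

Among the measured compounds shown here, only one measured step touches this chain: a 3.3-fold lower number from compound 2 to compound 3 (0.51 log units; beyond the scatter). That step is modest, though beyond the scatter, and it is a different change, (diethylamino)methyl in place of methoxycarbonyl. For the measured compounds named here, no measured pair shows a swap of diethylamino for dimethylamino, so the size of this step remains uncertain. Going by the values given here, with only this swap separating the two, the expected result is a 1.1-fold lower number from compound 3 to compound 4 (0.03 log units; within the scatter), which would lie within the scatter and have no clear direction. For compound 4, the estimated value is 5000 nM, with an expected range of 2300 nM to 11000 nM.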

Compound 4, half-maximal inhibitory concentration: 10100 nM
The estimate for compound 4 lay 2.0-fold (0.31 log units) below the measured number; low and high end bracket the measured number.
By their numbers in this assay, from the lowest: compound 1; then compounds 3, 4 and 2 (each within the scatter of the next, the first and the last beyond it).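

In this assay, the first direct test of the amine end of this chain, putting dimethylamino in place of diethylamino gives a step that stays within the scatter (a 1.9-fold higher number from compound 3 to compound 4 (0.28 log units; within the scatter)), so the two amines cannot be told apart here. The comparison with the methoxycarbonyl compound also changes: diethylamino gave a step beyond the scatter (a 3.3-fold lower number from compound 2 to compound 3 (0.51 log units; beyond the scatter)), whereas (dimethylamino)methyl in place of methoxycarbonyl gives one within it (a 1.7-fold lower number from compound 2 to compound 4 (0.24 log units; within the scatter)). Any effect of replacing the ester with an amine at this place therefore remains modest at best and depends on which amine is compared, and no supporting measurement explains these numbers.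

As far as these compounds go, it remains open whether a ring amine such as piperidine or a primary amine would shift the number beyond the scatter. A longer chain between the amide nitrogen and the amine is equally unresolved.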